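The source may hold more compounds than are shown below. What is called first, only, known or untested is meant among the compounds shown, and "the series" means these compounds.

The measured compounds, all tested in an assay on isolated protein for inhibition of Rho-associated protein kinase 2 (Homo sapiens), read by scintillation counting, radiometric assay and 33P incorporation, with a stated time of 40 min, in the presence of a further agent that is not named here; a lower number here means a stronger inhibitor, a higher number a weaker inhibitor:
compound 1, `Cc1ccc(C(=O)Nc2cccc(NC(=O)COc3ccc4c(=O)ccoc4c3)c2)cc1`, gives 22 nM;
compound 2, `O=C(COc1ccc2c(=O)ccoc2c1)Nc1cccc(NC(=O)c2ccc(Br)cc2)c1`, gives 49 nM;
compound 3, `Cc1cc(C(=O)Nc2cccc(NC(=O)COc3ccc4c(=O)ccoc4c3)c2)ccc1C(F)(F)F`, gives 43 nM.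

Compound 3 holds the second highest of these three numbers. Its closest neighbour is found by a 1.1-fold lower number from compound 2 to compound 3 (0.06 log units; within the scatter), and the furthest by a 2.0-fold higher number from compound 1 to compound 3 (0.29 log units; within the scatter); both steps lie within the scatter, so the three compounds cannot be ranked against each other.

Compound 4, `Cc1cc(C(=O)Nc2cccc(NC(=O)COc3ccc4c(=O)ccoc4c3)c2)no1`, has not yet been measured. It differs from compound 3 in one place: a group of 6 heavy atoms (4 carbon, 1 nitrogen, 1 oxygen; one five-membered aromatic ring with 2 hetero atoms) in place of a group of 11 heavy atoms (8 carbon, 3 fluorine; one six-membered aromatic ring of carbon only), on a carbonyl carbon. The three measured steps all alter the group on that same carbonyl carbon, but each swaps one benzene-containing group for another: a 2.2-fold higher number from compound 1 to compound 2 (0.35 log units; beyond the scatter), a 2.0-fold higher number from compound 1 to compound 3 (0.29 log units; within the scatter) and a 1.1-fold lower number from compound 2 to compound 3 (0.06 log units; within the scatter), all small. None of them exchanges a six-membered carbon ring for a five-membered ring with two hetero atoms, so they give only a loose guide. Since all exchanges at this carbonyl so far moved the number little, a modest step is expected for compound 4, more likely toward a higher number than a lower one, with wide uncertainty.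

Compound 4 is therefore estimated at 80 nM in this assay, within a range of 25 nM to 300 nM. This expected change amounts to a 1.9-fold higher number from compound 3 to compound 4 (0.27 log units; within the scatter).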

Compound 4, half-maximal inhibitory concentration: 5 nM
Compound 4: middle estimate off by 16-fold (1.20 log units), on the high side; the whole stated range lies above it.
By their numbers in this assay, from the lowest: compound 4; then compounds 1, 3 and 2 (each within the scatter of the next, the first and the last beyond it).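

At the carbonyl carbon whose other neighbour is an amide-type nitrogen, the three earlier compounds differed only by swapping one benzene-containing group for another, and that left the number little changed. Putting 5-methyl-1,2-oxazol-3-yl there gives a much larger shift in every comparison, (an 8.6-fold lower number from compound 3 to compound 4 (0.93 log units; beyond the scatter)), (a 9.8-fold lower number from compound 2 to compound 4 (0.99 log units; beyond the scatter)) and (a 4.4-fold lower number from compound 1 to compound 4 (0.64 log units; beyond the scatter)), which makes compound 4 the strongest inhibitor of the four. A benzene ring is therefore not required at this position, and a smaller five-membered aromatic ring with two hetero atoms does better than all three benzene-containing groups, though no measurement shown here explains this result.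

The compounds shown cannot separate the contribution of the methyl from that of the ring itself, so it remains open how a plain 1,2-oxazol-3-yl without the methyl would compare, or a five-membered thiazolyl or six-membered pyridyl group carrying its hetero atom differently. Also open, going by these compounds, is whether the same exchange would give a similar shift on a core other than the one shared by these four compounds.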